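This account rests on a few compounds, and the source may have more. Where it says the series, first, only, none or still open, it means among the compounds named here.

In a functional assay on NCI-H3122 cells (Homo sapiens) for antiproliferative activity, read by MTT assay, with a stated time of 48 h (a lower number here means a stronger inhibitor, a higher number a weaker inhibitor), three compounds have been measured so far. Compound 1 `CC(Oc1cccnc1Nc1cnn(C)c1)c1cccc(C(=O)NCc2ccc(OC(F)(F)F)cc2)c1` gives 8300 nM, and compound 3 `Cc1ccc(CNC(=O)c2cccc(C(C)Oc3ccnc(Nc4cn(C)nc4C)c3)c2)cc1` gives 13400 nM, so these two stand within the scatter of each other. Compound 2 `Cc1ccc(CNC(=O)c2cccc(C(C)Oc3cccnc3Nc3ncccn3)c2)cc1` returns no number, only a limit of the assay, > 100000 nM.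

The next compound, compound 4 `Cc1ccc(CNC(=O)c2cccc(C(C)Oc3ccnc(NN4CCCCC4)c3)c2)cc1`, keeps everything in compound 3 except one group: piperidin-1-yl comes in place of 1,3-dimethyl-1H-pyrazol-4-yl on a nitrogen on an aromatic ring, (piperidin-1-yl in place of 1,3-dimethyl-1H-pyrazol-4-yl on a nitrogen on an aromatic ring). The exchange puts a six-membered non-aromatic ring where a five-membered aromatic ring stood. For the measured compounds named here, no two measured compounds differ in one place only, so no measured step shows what such an exchange does in this assay.

The expectation therefore starts from compound 3 at 13400 nM and leans modestly toward weaker inhibition, with a result inside the scatter still plausible. A reading that is only a limit also remains possible, given (the limit of > 100000 nM in this assay, at which 1 of the 3 values shown sits). The expected change is a 2.2-fold higher number from compound 3 to compound 4 (0.35 log units; beyond the scatter). For compound 4 the estimated value is 30000 nM, with an expected range of 8000 nM to 100000 nM.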

Compound 4, half-maximal inhibitory concentration: 37400 nM
Compound 4: middle estimate off by 1.2-fold (0.10 log units), on the low side; the measured number falls inside the stated range.
By their numbers in this assay, from the lowest: compounds 1 and 3 (each within the scatter of the next); then compound 4. At a limit, above all of these: compound 2.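

In this assay, the group on a nitrogen on an aromatic ring can now be read through a single exchange: piperidin-1-yl in place of 1,3-dimethyl-1H-pyrazol-4-yl gives a 2.8-fold higher number from compound 3 to compound 4 (0.45 log units; beyond the scatter) and so costs a modest amount of inhibition, beyond the scatter. For the compounds shown here, this is the first sign that the group at this position matters, and the change is tolerated to the extent that compound 4 still gives a number, 37400 nM in this case, and not a limit of the assay. Going by these compounds alone, the single step records the size of the effect, but nothing measured here gives a cause for it.

The exchange swaps a five-membered aromatic ring for a six-membered non-aromatic one, so the compounds shown leave open whether the aromatic character, the ring size or the methyl groups account for the difference. A phenyl ring or a morpholin-4-yl group on this nitrogen, or a plain pyrazol-4-yl without its methyl groups, would begin to separate these features.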